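The source may report more compounds than this note shows. Statements on the series, on what has been measured and on what is new or still open speak of the compounds shown alone.

Measured compounds in this assay:
compound 1, `CS(=O)(=O)c1ccc(Nc2ncc(F)c(Nc3nc4ccccc4s3)n2)cc1`: 3270 nM
compound 2, `CS(=O)(=O)c1ccc(Nc2ncc(F)c(Nc3nc4ccc(Cl)cc4s3)n2)cc1`: 20700 nM
compound 3, `CS(=O)(=O)c1ccc(Nc2ncc(F)c(Nc3nc4ccc(F)cc4s3)n2)cc1`: > 50000 nM

All three share one core and differ only in the group on the fused ring. In a functional assay on HCT-116 cells (Homo sapiens) for antiproliferative activity, read by MTT assay, with a stated time of 48 h (a lower number here means a stronger inhibitor, a higher number a weaker inhibitor), compound 1 gives 3270 nM. Compound 2 gives 20700 nM. For compound 3 the assay reports only a limit, > 50000 nM, which is the limit of > 50000 nM in this assay, at which 1 of the 3 values shown sits. Compound 3 thus stands at the weak end of the numbers shown, with no exact value. The steps reaching it are both beyond the scatter: an at least 15-fold higher number from compound 1 to compound 3 (1.18 log units; beyond the scatter) and an at least 2.4-fold higher number from compound 2 to compound 3 (0.38 log units; beyond the scatter). The remaining step, a 6.3-fold higher number from compound 1 to compound 2 (0.80 log units; beyond the scatter), points the same way, so each substituent so far at this carbon has given a higher number than hydrogen.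

Compound 4, `COc1ccc2nc(Nc3nc(Nc4ccc(S(C)(=O)=O)cc4)ncc3F)sc2c1`, differs from compound 3 by methoxy in place of fluoro on an aromatic carbon. For the measured compounds named here, none of the measured steps introduces a methoxy, so the bearing of the three steps is indirect; they show only that this position has tolerated neither halogen. Because compound 3 sits at the limit > 50000 nM, the direction of the step cannot be fixed. The expectation for compound 4 is a number of the same weak order, estimated as 25000 nM within 5000 nM to 100000 nM, which for the step from compound 3 to compound 4 is estimated as an at least 2.0-fold lower number from compound 3 to compound 4 (0.30 log units; that floor lies within the scatter).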

Compound 4, half-maximal inhibitory concentration: 2630 nM
Beside the measured number, compound 4's estimate is 9.5-fold (0.98 log units) above it, and the stated range ends above it.
By their numbers in this assay, from the lowest: compounds 4 and 1 (each within the scatter of the next); then compound 2. At a limit, above all of these: compound 3.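

In this assay the earlier reading, that every substituent on this carbon gives a higher number than hydrogen, no longer holds for the series: compounds 2 and 3 still fit it, but compound 4 goes against it, and methoxy cannot be told apart from hydrogen here (a 1.2-fold lower number from compound 1 to compound 4 (0.09 log units; within the scatter)). The outcome at this carbon therefore depends on which group enters and not merely on whether a group is present, as methoxy separates clearly from chloro (a 7.9-fold lower number from compound 2 to compound 4 (0.90 log units; beyond the scatter)) and from fluoro (an at least 19-fold lower number from compound 3 to compound 4 (1.27 log units; beyond the scatter)). The step from fluoro gives only a minimum size, and the value for compound 3 is a limit and not a number: the limit of > 50000 nM in this assay, at which 1 of the 4 values shown sits.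

On these data alone, it remains open whether this tolerance extends beyond methoxy to other groups joined through oxygen, such as ethoxy or hydroxyl, or to groups such as methyl or an amine on the same carbon. As far as these compounds go, all four compounds vary at this one carbon, so it also remains open whether methoxy would behave the same way elsewhere on the fused ring, or whether any group here can give a number clearly lower than hydrogen.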